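From a Dimethylamino Chain to an Aminocyclohexyl Group

The source may report more compounds than this note shows. Statements on the series, on what has been measured and on what is new or still open speak of the compounds shown alone.

Measured in a functional assay on MCF7 cells (Homo sapiens) for cytotoxicity, read by fluorescence, with a stated time of 72 h; on this read-out lower numbers stand for stronger inhibition and higher numbers for weaker inhibition:
- compound 1 `CC(C)c1n[nH]c2c(NCc3ccc(-c4ccccn4)cc3)nc(N3CCCCC3CCO)nc12`: 133 nM
- compound 2 `CC(C)c1n[nH]c2c(NCc3ccc(-c4ccccn4)cc3)nc(NCCN)nc12`: 62 nM
- compound 3 `CC(C)c1n[nH]c2c(NCc3ccc(-c4ccccn4)cc3)nc(NCCN(C)C)nc12`: 225 nM

Compound 3, at 225 nM, lies at the upper end of these numbers but is not set apart from both neighbours. The data show a 1.7-fold higher number from compound 1 to compound 3 (0.23 log units; within the scatter), and also a 3.6-fold higher number from compound 2 to compound 3 (0.56 log units; beyond the scatter).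

Compound 4 `CC(C)c1n[nH]c2c(NCc3ccc(-c4ccccn4)cc3)nc(N[C@H]3CC[C@H](N)CC3)nc12` differs from compound 3 by a single exchange: 4-aminocyclohexyl in place of 2-(dimethylamino)ethyl on a nitrogen on an aromatic ring. In words, this is 4-aminocyclohexyl in place of 2-(dimethylamino)ethyl on a nitrogen on an aromatic ring.

Going by the values given here, no measured step covers this exchange directly, so the evidence is indirect. The closest guide is compound 2, which has amino where compound 3 has dimethylamino. Compound 2 gives 62 nM. A second guide is compound 1, which also carries a ring in this part of the molecule and gives 133 nM. The data show a 2.1-fold lower number from compound 1 to compound 2 (0.33 log units; beyond the scatter), a modest step of similar order. Among the compounds with values here, no measured compound tests the cyclohexyl ring or its defined stereocentres, so the uncertainty is wide.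

In this assay, a modest move toward a lower number is expected, with the estimate being a 3.8-fold lower number from compound 3 to compound 4 (0.57 log units; beyond the scatter). For compound 4 the estimated value is 60 nM, with an expected range from 15 nM to 220 nM.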

Compound 4, half-maximal inhibitory concentration: 474 nM
Compound 4: middle estimate off by 7.9-fold (0.90 log units), on the low side; the whole stated range lies below it.
By their numbers in this assay, from the lowest: compound 2; then compounds 1 and 3 (each within the scatter of the next); then compound 4.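

In this assay, the exchange of 2-(dimethylamino)ethyl for 4-aminocyclohexyl on a nitrogen on an aromatic ring goes toward weaker inhibition, with a 2.1-fold higher number from compound 3 to compound 4 (0.32 log units; beyond the scatter), which shows that this position does not reward the cyclohexyl ring in the way the amino-ended chain of compound 2 might have suggested. Set against the 2-aminoethyl group, the same position gives a 7.6-fold higher number from compound 2 to compound 4 (0.88 log units; beyond the scatter), the largest step in this set, so carrying an amino group is not enough by itself to keep the low number of compound 2. Against the 2-(2-hydroxyethyl)piperidin-1-yl group there is a 3.6-fold higher number from compound 1 to compound 4 (0.55 log units; beyond the scatter), which leaves compound 4 with the highest number of the four and shows that the two ring-bearing compounds, compound 1 and compound 4, do not sit together.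

The data shown give no measured account of why these numbers shift. From the compounds shown here alone, it also stays open how a 3-aminopropyl chain, a 4-hydroxycyclohexyl group or the 4-aminocyclohexyl group with the opposite arrangement at its stereocentres would read at this position, so the separate parts played by the ring, the chain length and the stereocentres cannot yet be told apart.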